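Bromo replaces trifluoromethoxy on a sulfonamide-linked aryl ring

The source may hold more compounds than are shown below. What is called first, only, known or untested is meant among the compounds shown, and "the series" means these compounds.

Two compounds share a core in which a methoxy-bearing aryl sulfonamide is joined to a pyridine carboxamide. Compound 1, `COc1ccc(Cl)cc1S(=O)(=O)Nc1cncc(C(N)=O)c1`, carries chloro on the aryl ring and in an assay on isolated protein for inhibition of alkaline phosphatase, tissue-nonspecific isozyme (Homo sapiens) (a lower number here means a stronger inhibitor, a higher number a weaker inhibitor), compound 1 gives 16 nM. Compound 2, `COc1ccc(OC(F)(F)F)cc1S(=O)(=O)Nc1cncc(C(N)=O)c1`, carries trifluoromethoxy in its place, and in this assay compound 2 gives 131 nM, which is the higher of the two numbers; the step is an 8.2-fold higher number from compound 1 to compound 2 (0.91 log units; beyond the scatter).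

Compound 3, `COc1ccc(Br)cc1S(=O)(=O)Nc1cncc(C(N)=O)c1`, differs from compound 2 by bromo in place of trifluoromethoxy on an aromatic carbon. For the measured compounds named here, the one measured step that bears on it is the move from compound 1 to compound 2, which raised the number when trifluoromethoxy took the place of chloro; compound 3 now reverses that by putting another halogen, bromo, where compound 1 has chloro. A step down in this assay toward the value of compound 1 is therefore expected, of a size comparable to an 8.2-fold higher number from compound 1 to compound 2 (0.91 log units; beyond the scatter) though in the opposite direction. The estimated step to compound 3 is a 6.6-fold lower number from compound 2 to compound 3 (0.82 log units; beyond the scatter).

Compound 3 is thus estimated at 20 nM in this assay, with a range from 8 nM to 60 nM.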

Compound 3, half-maximal inhibitory concentration: 14 nM
Estimate against measurement, compound 3: 1.4-fold (0.15 log units) above; the range from low to high includes it.
By their numbers in this assay, from the lowest: compounds 3 and 1 (each within the scatter of the next); then compound 2.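

In this assay, the swap on this aromatic carbon, para to a methoxy group, gives a 9.4-fold lower number from compound 2 to compound 3 (0.97 log units; beyond the scatter) and so shows that the higher number of compound 2 is not fixed by the shared core, since a different group at the same place brings it back to the level seen with chloro. The other new comparison, a 1.1-fold lower number from compound 1 to compound 3 (0.06 log units; within the scatter), adds that chloro and bromo cannot be told apart at this position, which the earlier pair could not show, so among these three compounds the two single-atom halogens stand together and the five-heavy-atom trifluoromethoxy of compound 2 alone stands apart. No measurement offered here accounts for this difference between the groups.

The compounds shown leave open whether this level is particular to chloro and bromo or is shared by fluoro, methyl or a nitrile, and how an amine, a carboxylic acid or a longer alkyl chain would fare on the same carbon. They also leave open whether the match between chloro and bromo would survive a change elsewhere, such as ethoxy in place of the methoxy group.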